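From piperidin-1-yl to azepan-1-yl on a shared core

The source may report more compounds than this note shows. Statements on the series, on what has been measured and on what is new or still open speak of the compounds shown alone.

Compound 2 (`Clc1ccc2c(NCCCn3cnc4c(N5CCCCC5)nc(Cl)nc43)ccnc2c1`) stands in an ADME assay on Vero cells (Chlorocebus sabaeus) for cytotoxicity, read by neutral red uptake, with a stated time of 48 h (on this read-out lower numbers stand for stronger inhibition and higher numbers for weaker inhibition), at > 10400 nM as a limit of the assay and not a number. In this assay compound 1 (`Clc1ccc2c(NCCCn3cnc4c(N5CCCC5)nc(Cl)nc43)ccnc2c1`) gives > 10700 nM as a limit too. No measured number is therefore available for either compound. Compound 3 (`Clc1ccc2c(NCCCn3cnc4c(N5CCCCCC5)nc(Cl)nc43)ccnc2c1`) differs from compound 2 in one place, with azepan-1-yl in place of piperidin-1-yl on an aromatic carbon. Among the compounds with values here, one measured step bears on this change, the exchange of pyrrolidin-1-yl for piperidin-1-yl (a step that the two limits leave unreadable from compound 1 to compound 2), and it offers no size to carry forward. In this assay the step expected is an at least 1.0-fold lower number from compound 2 to compound 3 (0.01 log units; that floor lies within the scatter) with no direction to argue, so nothing beyond the scatter is anticipated. For compound 3 the estimated value is 10000 nM in a range from 4000 nM to 20000 nM and the result may well again be only a limit.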

Compound 3, half-maximal inhibitory concentration: > 10100 nM
Compound 3 gave a limit, no number (the forecaster's own chance of this, stated with the estimate: 75%); middle value at least 1.0-fold (0.00 log units) from the limit.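

In this assay, within the data shown here, compound 1, compound 2 and compound 3 each give only a limit and not a number, so no step among them can be read. The compounds shown leave open whether pyrrolidin-1-yl, piperidin-1-yl and azepan-1-yl differ at all in this assay.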